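This account rests on a few compounds, and the source may have more. Where it says the series, first, only, none or still open, it means among the compounds named here.

Working notes on the series

Compound 1 `c1ccc(-[n+]2c[nH]c3ncncc32)cc1` and compound 2 `Fc1ccc(-[n+]2c[nH]c3ncncc32)cc1` share one core; compound 3 `Fc1ccc(Cn2cnc3c(Sc4ccccc4)ncnc32)cc1` and compound 4 `Fc1ccc(Cn2cnc3c(Sc4ccc(F)cc4)ncnc32)cc1` share another, and the difference between the two cores is not broken down here. In an assay on isolated protein for inhibition of RAC-alpha serine/threonine-protein kinase (Homo sapiens), tested at 30 uM (a lower number here means less inhibition, a higher number more inhibition at the concentration tested (going by the name of the read-out)), compound 1 gives 0% and compound 2 gives 0%. The change (fluoro in place of hydrogen on an aromatic carbon), whose place is para to a group of 9 heavy atoms, gives no change at the digits printed from compound 1 to compound 2 (within the scatter). Compound 3 gives 13% in this assay, the highest of the three numbers and beyond the scatter from both compound 1 and compound 2.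

Compound 4 carries the same kind of change, (fluoro in place of hydrogen on an aromatic carbon), where the place is para to a large group rather than para to a group of 9 heavy atoms. Among the measured compounds shown here, the one measured instance of this change is from compound 1 to compound 2, and it made no step beyond the scatter. On that basis the step from compound 3 to compound 4 is expected to be no change at the digits printed from compound 3 to compound 4 (within the scatter). Compound 4 is therefore estimated at 13% in this assay, with a likely range from 3% to 25%, resting on the unchanged pair and on the value of compound 3.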

Compound 4, a percentage reported as inhibition, at one concentration (the size of the read-out at that concentration, not a potency): 0%
Beside the measured number, compound 4's estimate is 13 percentage points above it; measured number below the stated range.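

In this assay the new step reads a number 13 percentage points lower from compound 3 to compound 4 (beyond the scatter), and set against the earlier step it gives no firm difference between the two cores: the same change on two cores in this assay, no change at the digits printed (within the scatter) from compound 1 to compound 2 and a number 13 percentage points lower (beyond the scatter) from compound 3 to compound 4, 13 percentage points apart, within the scatter of two such steps. Among the compounds shown here, the fluoro change therefore cannot be said to act differently on the two cores, even though only the step on the core of compound 3 lies beyond the scatter. Nor does this show that the change carries over unaltered, since there are only two pairs and compound 1 already gives 0%, so the first step starts from a number that leaves no room for a fall on this read-out.

Still open, on these data alone, is how the phenylsulfanyl group responds to a replacement other than fluoro, such as chloro, methoxy or an amine on the same ring. Also open, as far as these compounds go, is whether any group on either core would give clearly more inhibition than compound 3 does; compound 3 gives 13%.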